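Bromo for nitro on the pendant ring: two placements

The source may report more compounds than this note shows. Statements on the series, on what has been measured and on what is new or still open speak of the compounds shown alone.

Measured so far:
compound 1, `Brc1cccc(-c2nc3ncccc3o2)c1`, 23%
compound 2, `O=[N+]([O-])c1ccccc1-c1nc2cccnc2o1`, 57%
compound 3, `O=[N+]([O-])c1cccc(-c2nc3ncccc3o2)c1`, 21%

All three were run in a functional assay on the whole organism for inhibition, with Rattus norvegicus as the target, at a dose of 30 mg/kg; on this read-out higher numbers stand for more inhibition at the one dose given (going by the name of the read-out) and lower numbers for less inhibition. Compound 2 stands highest of the three; compound 1 lies a number 2 percentage points higher from compound 3 to compound 1 (within the scatter). The difference between compound 2 and compound 3 is not broken down here.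

Compound 4, `Brc1ccccc1-c1nc2cccnc2o1`, is not yet measured in this assay. It differs from compound 2 by bromo in place of nitro on an aromatic carbon. The same kind of change separates compound 1 from compound 3, (bromo in place of nitro on an aromatic carbon); the two places are not identical, one being ortho to a group of 9 heavy atoms and the other meta to a group of 9 heavy atoms, so the change is of the same kind, not the same.

In this assay the step from compound 2 to compound 4 is expected to be a number 5 percentage points lower from compound 2 to compound 4 (within the scatter) because the related exchange gave a number 2 percentage points higher from compound 3 to compound 1 (within the scatter). Compound 4 is thus estimated at 52%, with a range of 30% to 70%. Going by the values given here, the single precedent and the differing place leave this estimate loosely held.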

Compound 4, a percentage reported as inhibition, in the whole organism at one dose (the size of the read-out at that dose, not a potency): 31%
Compound 4: middle estimate off by 21 percentage points, on the high side; measured number inside the range.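

In this assay, bromo in place of nitro ortho to a group of 9 heavy atoms gives a clear loss, a number 26 percentage points lower from compound 2 to compound 4 (beyond the scatter). The exchange therefore does not carry over as a fixed increment within this series: the same change on two cores in this assay, a number 2 percentage points higher (within the scatter) from compound 3 to compound 1 and a number 26 percentage points lower (beyond the scatter) from compound 2 to compound 4, 28 percentage points apart, beyond the scatter of two such steps What this does not show is why the two steps part, since two pairs cannot separate the place of the exchange from any other cause, and they support no general rule for how bromo and nitro compare across the series.

The compounds shown leave open whether the higher number of compound 2 belongs to nitro alone, or whether an amine or a carboxylic acid on the same aromatic carbon would reach a similar number. Also open, going by these compounds, is whether the exchange would follow either of the two steps on the pendant ring of a different core, or at other doses.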